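Short-Linker Anilide Replacing a Dichlorophenyl Methylamide

A few compounds are considered here, and "the series" means these few. Any claim that something is new, unique, unknown or untested is made for them only; others in the source may bear on it.

Measured compounds:
Compound 1 `Cn1c(Cc2nn(C)c(=O)c3ccccc23)nnc1SCCCCCCCC(=O)Nc1ccc(Br)cc1Br`: 1500 nM
Compound 2 `CN(C(=O)CSc1nnc(Cc2nn(C)c(=O)c3ccccc23)n1C)c1ccc(Cl)cc1Cl`: > 30000 nM
Compound 3 `Cn1c(Cc2nn(C)c(=O)c3ccccc23)nnc1SCCCCCCCCCCC(=O)Oc1ccc(Cl)cc1Cl`: 8700 nM

Of the compounds shown here, three sharing one core have been measured in an assay on isolated protein (Mus musculus) for inhibition of IL15-IL15 receptor (Homo sapiens), read by resazurin assay, with stated times of 30 min and 2.5 days; on this read-out higher numbers stand for weaker inhibition and lower numbers for stronger inhibition. Compound 1 gives 1500 nM and compound 3 gives 8700 nM. For compound 2 only a limit of the assay is reported, > 30000 nM, so no number places it among the others; it sits at the limit of > 30000 nM in this assay, at which 1 of the 3 values shown sits, the weakest end of what the assay can report.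

Compound 4 `COc1ccc(NC(=O)CSc2nnc(Cc3nn(C)c(=O)c4ccccc34)n2C)cc1` keeps the short chain of compound 2 and differs from it in one place: (4-methoxyphenyl)amino in place of (2,4-dichlorophenyl)(methyl)amino on a carbonyl carbon. Going by the values given here, no pair of measured compounds differs in a single place, so no measured step guides the size of this change. Since compound 2 stands only at a limit, the step from compound 2 to compound 4 in this assay cannot be sized from the data; the estimate that follows amounts to an at least 1.5-fold lower number from compound 2 to compound 4 (0.17 log units; that floor lies within the scatter), an expected move back into the measurable range at best.

Compound 4 is therefore expected to show roughly 20000 nM in this assay, within 5000 nM to 60000 nM, with a fair chance that only a limit is again reported.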

Compound 4, half-maximal inhibitory concentration: "not active" (no number reported)
The entry for compound 4 holds no number, and the estimate cannot be compared.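

In this assay, going by these compounds alone, compound 4 is reported as not active, with no number, and compound 2 stands only at a limit, so no step from compound 2 to compound 4 can be read. The compounds shown leave open whether (4-methoxyphenyl)amino in place of (2,4-dichlorophenyl)(methyl)amino changes inhibition at all.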